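A Methoxyphenyl Swap on the Carbonyl of Compound 1

The compounds below may be only part of what the source reports. "The series", "measured", "known", "first", "only" and "open" are said of these compounds alone.

Compound 1 `COc1cc(-c2nnc3n2NC(c2ccco2)C(C(=O)c2ccc(F)cc2)S3)cc(OC)c1OC` was tested in a functional assay on PC-3 cells (Homo sapiens) for cytotoxicity, read by MTT assay, with a stated time of 48 h (on this read-out lower numbers stand for stronger inhibition and higher numbers for weaker inhibition), where compound 1 gives 27700 nM. Compound 2 `COc1cc(-c2nnc3n2NC(c2cccs2)C(C(=O)c2ccc(Cl)cc2)S3)cc(OC)c1OC` was run in the same way, and in this assay compound 2 gives 32500 nM. Among the compounds with values here, of the two numbers, the one for compound 1 stands lowest, but the gap to compound 2 is within the usual scatter, so the two compounds read as equivalent on this read-out. Compound 3 `COc1cccc(C(=O)C2Sc3nnc(-c4cc(OC)c(OC)c(OC)c4)n3NC2c2ccco2)c1` has not yet been measured. It differs from compound 1 in a single place: 3-methoxyphenyl in place of 4-fluorophenyl on a carbonyl carbon. Within the data shown here, no measured pair in this set shows the same change, so there is no direct precedent for the size of the step. Compound 3 is therefore expected to stay close to compound 1, with a 1.1-fold higher number from compound 1 to compound 3 (0.03 log units; within the scatter) expected to fall within the scatter in either direction. The estimate for compound 3 in this assay is 30000 nM, expected to lie between 12000 nM and 75000 nM.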

Compound 3, half-maximal inhibitory concentration: 84600 nM
Estimate against measurement, compound 3: 2.8-fold (0.45 log units) below; measured number above the stated range.
By their numbers in this assay, from the lowest: compounds 1 and 2 (each within the scatter of the next); then compound 3.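

In this assay, the group on this carbonyl carbon proves able to move the number: 3-methoxyphenyl in place of 4-fluorophenyl gives a 3.1-fold higher number from compound 1 to compound 3 (0.48 log units; beyond the scatter) on an otherwise unchanged molecule. The step is modest but beyond the scatter, and it points toward weaker inhibition. Within the data shown here, compound 1 and compound 2 could not show this, as they differ in more than one place and offer no step that isolates this position. Nothing here explains why the number rises.

Still open, on these data alone, is whether the methoxy group itself or its place on the ring matters, a question that 3-fluorophenyl and 4-methoxyphenyl on the same carbonyl carbon could help separate. Also open, as far as these compounds go, is how a 4-aminophenyl group or a 4-carboxyphenyl group would read at this position.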